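Swapping the Aryl Group: Three Measured, One Estimated

The source may report more compounds than this note shows. Statements on the series, on what has been measured and on what is new or still open speak of the compounds shown alone.

All three measured compounds were tested in a functional assay on K562 cells (Homo sapiens) for antiproliferative activity, with a stated time of 72 h; a higher number here means a weaker inhibitor, a lower number a stronger inhibitor.
Compound 1 `OC[C@H]1O[C@@H](n2cnc3c(NCc4ccccc4F)ncnc32)[C@H](O)[C@@H]1O`: 33200 nM
Compound 2 `Cc1cccc(CNc2ncnc3c2ncn3[C@@H]2O[C@H](CO)[C@@H](O)[C@H]2O)c1`: > 166000 nM
Compound 3 `OC[C@H]1O[C@@H](n2cnc3c(NCc4ccc(Cl)cc4Cl)ncnc32)[C@H](O)[C@@H]1O`: 106000 nM

The value for compound 2 is a limit, not a number (the limit of > 166000 nM in this assay, at which 1 of the 3 values shown sits). Among the numbers shown, compound 1 stands lowest, with compound 3 nearest. Compound 4 `COc1cccc(CNc2ncnc3c2ncn3[C@@H]2O[C@H](CO)[C@@H](O)[C@H]2O)c1OC` differs from compound 1 in one place: 2,3-dimethoxyphenyl in place of 2-fluorophenyl on a saturated chain carbon bound to a nitrogen on an aromatic ring. Two measured steps alter the same aryl group: an at least 5.0-fold higher number from compound 1 to compound 2 (0.69 log units; beyond the scatter) and a 3.2-fold higher number from compound 1 to compound 3 (0.50 log units; beyond the scatter). Both raised the number beyond the scatter, so a modest rise is expected here as well, in this assay. Compound 4 is therefore estimated at 100000 nM, within 40000 nM to 250000 nM. That estimate means a 3.0-fold higher number from compound 1 to compound 4 (0.48 log units; beyond the scatter).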

Compound 4, half-maximal inhibitory concentration: > 166000 nM
Compound 4 was reported as a limit (the forecaster's own chance of this, stated with the estimate: 25%); at least 1.6-fold (0.22 log units) between middle value and limit.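

In this assay, compound 4 is reported only as a limit, the second compound shown to sit there: the limit of > 166000 nM in this assay, at which 2 of the 4 values shown sit. The 2,3-dimethoxyphenyl group, the first replacement carrying oxygen, gives an at least 5.0-fold higher number from compound 1 to compound 4 (0.69 log units; beyond the scatter), so all three replacements of 2-fluorophenyl at this place raise the number beyond the scatter. The change from 2,4-dichlorophenyl gives an at least 1.5-fold higher number from compound 3 to compound 4 (0.19 log units; that floor lies within the scatter), which sets no order, and the step from compound 2 to compound 4 cannot be read.

As far as these compounds go, whether an amine or a carboxylic acid on the aryl group, or a longer chain carrying it, would bring the number below that of compound 1 stays open.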